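Hydroxyurea amides: cyclohexyl to cyclopentyl on the amide nitrogen

The source may hold more compounds than are shown below. What is called first, only, known or untested is meant among the compounds shown, and "the series" means these compounds.

compound 1 `CCC(C)C(NC(=O)NO)C(=O)NC1CCCCC1` — > 100000 nM
compound 2 `CCC(C)C(NC(=O)NO)C(=O)NC(c1ccccc1)c1ccccc1` — >= 100000 nM

In a functional assay on SW-620 cells (Homo sapiens) for inhibition (on this read-out lower numbers stand for stronger inhibition and higher numbers for weaker inhibition), compound 1 gives > 100000 nM, a limit of the assay rather than a number. In this assay compound 2 gives >= 100000 nM, also a limit. Compound 1 thus stands at the limit of > 100000 nM in this assay, at which 1 of the 2 values shown sits. The second value shown sits at the limit of >= 100000 nM in this assay, at which 1 of the 2 values shown sits. Compound 3 `CCC(C)C(NC(=O)NO)C(=O)NC1CCCC1` differs from compound 1 by cyclopentyl in place of cyclohexyl on an amide-type nitrogen. Among the compounds with values here, no measured step between any two compounds exists here, so the size of this change cannot be read from the data. The expectation is no movement beyond the scatter, a step that the limit leaves unreadable from compound 1 to compound 3. Compound 3 is expected to give 150000 nM, between 50000 nM and 500000 nM, most probably again reported only as a limit.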

Compound 3, half-maximal inhibitory concentration: > 100000 nM
Compound 3 was reported as a limit; the forecaster's own chance of this, stated with the estimate: 85%; the middle value lies beyond the limit too.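

In this assay compound 3 gives > 100000 nM, a limit and not a number. Within the data shown here, compound 1 is also reported as a limit, and no step from compound 1 to compound 3 can be read. The compounds shown leave open whether cyclopentyl and cyclohexyl on an amide-type nitrogen differ at all in this assay.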